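The source may hold more compounds than are shown below. What is called first, only, known or untested is meant among the compounds shown, and "the series" means these compounds.

Compounds in an ADME assay on Huh-7 cells (Homo sapiens) for cytotoxicity, with a stated time of 72 h; on this read-out lower numbers stand for higher toxicity in this test and higher numbers for lower toxicity in this test:
Compound 1 `CC(C)CCn1nc(-c2cncs2)c(O)c(C2=NS(=O)(=O)c3cc(NS(C)(=O)=O)ccc3N2)c1=O`: > 33000 nM, a limit
Compound 2 `CC(C)CCn1nc(C2CCCCC2)c(O)c(C2=NS(=O)(=O)c3cc(NS(C)(=O)=O)ccc3N2)c1=O`: > 1000 nM, a limit
Compound 3 `CC(C)CCn1nc(C2CCCC2)c(O)c(C2=NS(=O)(=O)c3cc(NS(C)(=O)=O)ccc3N2)c1=O`: not yet measured

Compound 2 has no exact value on this read-out: compound 2 stands at > 1000 nM, which is a limit and not a number. Compound 1 also stands only at a limit, > 33000 nM.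

The change from compound 2 to compound 3 is cyclopentyl in place of cyclohexyl on an aromatic carbon. It puts cyclopentyl in place of cyclohexyl on an aromatic carbon, next to the ring nitrogen and ortho to a hydroxy group.

Within the data shown here, only one measured step bears on this place, a step that the two limits leave unreadable from compound 1 to compound 2. Its size cannot be read, so it offers no measured guide to either size or direction. No step beyond the usual scatter is therefore expected in this assay from this small change of ring. The expected step that the limit leaves unreadable from compound 2 to compound 3 is counted from a limit, so it is only a rough estimate, and a further limit is the likeliest report. For compound 3 the estimated value is 10000 nM, with an expected range from 1500 nM to 40000 nM.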

Compound 3, half-maximal cytotoxic concentration: > 1000 nM
Compound 3 gave a limit, no number (the forecaster's own chance of this, stated with the estimate: 70%); the middle value lies beyond the limit too.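

In this assay compound 3 gives > 1000 nM, which is a limit and not a number. Its steps from compound 2 and from compound 1 therefore cannot be read. The compounds shown leave open whether cyclopentyl, cyclohexyl and 1,3-thiazol-5-yl differ at all in this assay, and where any exact half-maximal cytotoxic concentration lies.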